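Ring-nitrogen substituent change, compound 2 to compound 3

The source may hold more compounds than are shown below. What is called first, only, known or untested is meant among the compounds shown, and "the series" means these compounds.

Among the measured compounds shown here, compound 2 `Nc1ccccc1NC(=O)c1ccc(CSC(=S)N2CCN(c3ccccc3F)CC2)cc1` gives 59.2% in a functional assay on HeLa cells (Homo sapiens) for antiproliferative activity, read by CCK-8 assay, with a stated time of 72 h, tested at 8 uM (a lower number here means a weaker effect, a higher number a stronger effect of the compound at the concentration tested), the lower of the two numbers measured so far; compound 1 `Nc1ccccc1NC(=O)c1ccc(CSC(=S)N2CCN(Cc3cccnc3)CC2)cc1` gives 78%. For the measured compounds named here, the only measured step, a number 18.8 percentage points lower from compound 1 to compound 2 (beyond the scatter), exchanged a group containing a pyridine for a fluorophenyl. Compound 3 `Nc1ccccc1NC(=O)c1ccc(CSC(=S)N2CCN(c3ccncc3)CC2)cc1` partly reverses this: pyridin-4-yl in place of 2-fluorophenyl on an amine nitrogen in a ring. A pyridine returns, yet it sits on the amine nitrogen in a ring exactly as the fluorophenyl of compound 2 did, so the earlier step bears on it only loosely. A small rise is expected, a number 6.8 percentage points higher from compound 2 to compound 3 (within the scatter), probably within the scatter. Compound 3 is estimated at 66%, range 48% to 82%.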

Compound 3, a percentage reported as inhibition, at one concentration (the size of the read-out at that concentration, not a potency): 77.4%
Compound 3: middle estimate off by 11.4 percentage points, on the low side; the range from low to high includes it.
By their numbers in this assay, from the lowest: compound 2; then compounds 3 and 1 (each within the scatter of the next).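

Having an aromatic ring directly on the amine nitrogen in a ring does not by itself set the level in this assay: the exchange of 2-fluorophenyl for pyridin-4-yl gives a number 18.2 percentage points higher from compound 2 to compound 3 (beyond the scatter) and so separates these two directly attached rings. The directly attached pyridin-4-yl and the (pyridin-3-yl)methyl group are not told apart, with a number 0.6 percentage points lower from compound 1 to compound 3 (within the scatter) as the step between them. No measurement at hand explains either step.

Still open, going by these compounds, is whether the difference between these two rings follows the ring nitrogen of the pyridin-4-yl or the fluorine of the 2-fluorophenyl. An unsubstituted phenyl at this position would separate the two.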